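Notes on amide-tail variation in a spiro-series

The compounds below may be only part of what the source reports. "The series", "measured", "known", "first", "only" and "open" are said of these compounds alone.

Measured so far:
compound 1, `CC(C)(C)OC(=O)NC1CCCN(C(=O)CN2CN(c3ccccc3)C3(CCN(C(=O)c4ccc(C5CCCCC5)cc4)CC3)C2=O)C1`, 4400 nM
compound 2, `COC(=O)CCCNC(=O)CN1CN(c2ccccc2)C2(CCN(C(=O)c3ccc(C4CCCCC4)cc3)CC2)C1=O`, 2500 nM
compound 3, `CC(C)(C)OC(=O)NCCCCNC(=O)CN1CN(c2ccccc2)C2(CCN(C(=O)c3ccc(C4CCCCC4)cc3)CC2)C1=O`, 4600 nM

All three values come from an assay on HEK293 cells for displacement of a labelled ligand from NPC1-like intracellular cholesterol transporter 1 (Homo sapiens); a higher number here means a weaker inhibitor, a lower number a stronger inhibitor. The three numbers sit close together: compound 2 gives the smallest of them, but compound 1 and compound 3 each differ from compound 2 by less than the usual scatter, so nothing separates them. Among the compounds with values here, the one step measured, a 1.8-fold higher number from compound 2 to compound 3 (0.26 log units; within the scatter), exchanges the tail of the same amide side chain and changes the read-out by nothing beyond scatter.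

Compound 4, `NC(=O)C1CCCN(C(=O)CN2CN(c3ccccc3)C3(CCN(C(=O)c4ccc(C5CCCCC5)cc4)CC3)C2=O)C1`, is not yet measured in this assay. Against compound 2 it shows (3-carbamoylpiperidin-1-yl in place of (3-(methoxycarbonyl)propyl)amino on a carbonyl carbon). Compound 1 already carries a piperidin-1-yl on this carbonyl carbon and gives a number close to compound 2 and compound 3. Together with the flat step in this assay, the expectation is no step beyond the scatter. Compound 4 is estimated at 3200 nM, within 1300 nM to 8000 nM. The expected step reads a 1.3-fold higher number from compound 2 to compound 4 (0.11 log units; within the scatter).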

Compound 4, half-maximal inhibitory concentration: 3100 nM
Compound 4: middle estimate off by 1.0-fold (0.01 log units), on the high side; low and high end bracket the measured number.
By their numbers in this assay, from the lowest: compounds 2, 4, 1 and 3 (each within the scatter of the next).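

The position tolerates more than the earlier tail exchange showed: in this assay, a ring-bearing 3-carbamoylpiperidin-1-yl on the carbonyl carbon, in place of the open-chain (3-(methoxycarbonyl)propyl)amino, gives a 1.2-fold higher number from compound 2 to compound 4 (0.09 log units; within the scatter) and so stays within the scatter. With the piperidine ring kept, the group on the saturated ring carbon can also be exchanged without a step beyond the scatter: carbamoyl in place of (tert-butoxycarbonyl)amino gives a 1.4-fold lower number from compound 1 to compound 4 (0.15 log units; within the scatter). No measurement at hand accounts for this flat behaviour.

All four compounds remain within the scatter of one another, so nothing yet shows which features of this tail, if any, affect the read-out. Open, as far as these compounds go, is whether a free primary amine, a carboxylic acid or a much longer chain at this position would produce a step beyond the scatter.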